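A few compounds are considered here, and "the series" means these few. Any claim that something is new, unique, unknown or untested is made for them only; others in the source may bear on it.

Compounds measured so far:
- compound 1, `COc1ccccc1C(=O)NC(=S)NNc1ncnc2ccccc12`: 15700 nM
- compound 2, `O=C(NC(=S)NNc1ncnc2ccccc12)c1ccc(F)cc1`: 2840 nM

For the measured compounds named here, in a functional assay on CNE-2 cells (Homo sapiens) for cytotoxicity, read by MTT assay, with a stated time of 72 h (a lower number here means a stronger inhibitor, a higher number a weaker inhibitor), compound 2 stands lowest of the two numbers; the single measured step between them is a 5.5-fold lower number from compound 1 to compound 2 (0.74 log units; beyond the scatter). Compound 3 is `O=C(NC(=S)NNc1ncnc2ccccc12)c1ccccc1`. It differs from compound 2 by hydrogen in place of fluoro on an aromatic carbon, on an aromatic carbon of a six-membered aromatic ring of carbon only, para to a large group. Going by the values given here, only one step has been measured, and it exchanged a 2-methoxyphenyl for a 4-fluorophenyl on the carbonyl carbon; it therefore changes both the position and the kind of substituent at once and does not isolate the fluoro. The fluoro in compound 2 may carry part of that gain, so compound 3 is expected to lie within the scatter of compound 2 or a little higher. Compound 3 is expected to give about 4200 nM, with a range from 1500 nM to 12000 nM. The expected step is a 1.5-fold higher number from compound 2 to compound 3 (0.17 log units; within the scatter).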

Compound 3, half-maximal inhibitory concentration: 1490 nM
Estimate against measurement, compound 3: 2.8-fold (0.45 log units) above; the measured number lies below the stated range.
By their numbers in this assay, from the lowest: compounds 3 and 2 (each within the scatter of the next); then compound 1.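

In this assay, taking the fluoro off the 4-fluorophenyl gives a 1.9-fold lower number from compound 2 to compound 3 (0.28 log units; within the scatter), so the fluoro on this aromatic carbon, para to a large group, is not required for the level seen with compound 2. The plain phenyl also separates what the earlier step had combined: hydrogen in place of methoxy gives an 11-fold lower number from compound 1 to compound 3 (1.02 log units; beyond the scatter), which ties the high number of compound 1 to its methoxy and not to a missing fluoro. Nothing available explains either step.

The compounds shown leave open whether a chloro, a methyl or an amine on the same aromatic carbon would move the number beyond the scatter of compound 3. They also leave open whether a methoxy placed there would give a number like that of compound 1.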